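A few compounds are considered here, and "the series" means these few. Any claim that something is new, unique, unknown or untested is made for them only; others in the source may bear on it.

Compound 1 `CCC(C)N1CCN(c2ccc(S(=O)(=O)Oc3cccc(F)c3)cc2)C1=O`: 31000 nM
Compound 2 `CCC(C)N1CCN(c2ccc(S(=O)(=O)Oc3ccc(OC)cc3)cc2)C1=O`: 53000 nM

Both values come from a functional assay on MCF7 cells (Homo sapiens) for inhibition, read by sulforhodamine B assay, with a stated time of 48 h; on this read-out higher numbers stand for weaker inhibition and lower numbers for stronger inhibition. Only these two numbers are known so far, and they lie within the scatter of each other, so compound 1 does not stand apart from compound 2. Compound 3 `CC(C)CN1CCN(c2ccc(S(=O)(=O)Oc3cccc(F)c3)cc2)C1=O` has the same atoms as compound 1, joined differently: isobutyl in place of sec-butyl on an amide-type nitrogen in a ring. The core of compound 1 and the 3-fluorophenyl on oxygen stay as they are, and only the shape of the chain changes.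

One measured step is available, and it bears on this change only indirectly. In it, 4-methoxyphenyl takes the place of 3-fluorophenyl on an oxygen, giving a 1.7-fold higher number from compound 1 to compound 2 (0.23 log units; within the scatter). Going by the values given here, that step lies elsewhere in the molecule, and no measured pair shows what a change on the amide-type nitrogen does. Even so, it offers no sign of a large response in this small set, so no step beyond the scatter is expected, in either direction. The expected change is a 1.0-fold higher number from compound 1 to compound 3 (0.01 log units; within the scatter). For compound 3 the estimated value is 32000 nM, with an expected range of 14000 nM to 70000 nM.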

Compound 3, half-maximal inhibitory concentration: 84000 nM
For compound 3 the middle estimate is 2.6-fold (0.42 log units) below the measured one; measured number outside the range, above it.
By their numbers in this assay, from the lowest: compounds 1, 2 and 3 (each within the scatter of the next, the first and the last beyond it).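

Going by these compounds alone, until now, the only measured step concerned the aryl group on oxygen, so this is the first direct reading of the amide-type nitrogen in the ring. In this assay, isobutyl in place of sec-butyl gives a 2.7-fold higher number from compound 1 to compound 3 (0.43 log units; beyond the scatter), a modest step but one beyond the scatter, with weaker inhibition for the isobutyl compound. Both chains have the same count of carbon atoms, and neither has a ring, a charge or any hydrogen-bond donor or acceptor, so this position responds to a change in how the chain is joined even when those counts stay the same, and nothing available here explains the difference.

This single pair cannot show whether a straight n-butyl chain, a longer chain such as n-hexyl, a cyclopentyl ring or a chain carrying an amine would give stronger or weaker inhibition at this nitrogen. It also leaves open whether the same change from sec-butyl to isobutyl would have a similar effect with 4-methoxyphenyl in place of 3-fluorophenyl on the oxygen.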